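Swapping Furan for Thiophene on a Shared Core

The source may report more compounds than this note shows. Statements on the series, on what has been measured and on what is new or still open speak of the compounds shown alone.

Three compounds share one core and differ only in the group attached to it. Compound 1 `CCOC(=O)c1cnn(-c2nc(-c3ccccc3F)c(C#N)c(=O)n2C)c1N` carries a 2-fluorophenyl group; in a functional assay, with a stated time of 150 min (a higher number here means a weaker inhibitor, a lower number a stronger inhibitor), compound 1 gives 87 ug/mL. Compound 2 `CCOC(=O)c1cnn(-c2nc(-c3cccc(OC)c3OC)c(C#N)c(=O)n2C)c1N` carries a 2,3-dimethoxyphenyl group, and in this assay compound 2 gives 69 ug/mL. Compound 3 `CCOC(=O)c1cnn(-c2nc(-c3ccco3)c(C#N)c(=O)n2C)c1N` carries a furan-2-yl group, and in this assay compound 3 gives 108 ug/mL. Compound 3 gives the largest of the three numbers, yet a 1.2-fold higher number from compound 1 to compound 3 (0.09 log units; within the scatter) and a 1.6-fold higher number from compound 2 to compound 3 (0.19 log units; within the scatter) both lie within the scatter, so the three compounds cannot be told apart on these data.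

Compound 4 `CCOC(=O)c1cnn(-c2nc(-c3cccs3)c(C#N)c(=O)n2C)c1N` has not yet been measured. It differs from compound 3 in one place: thiophen-2-yl in place of furan-2-yl on an aromatic carbon. Within the data shown here, none of the measured steps replaces a furan-2-yl group with a thiophen-2-yl group, so no direct guide exists. The steps that do exist, a 1.3-fold lower number from compound 1 to compound 2 (0.10 log units; within the scatter), a 1.2-fold higher number from compound 1 to compound 3 (0.09 log units; within the scatter) and a 1.6-fold higher number from compound 2 to compound 3 (0.19 log units; within the scatter), all stayed within the scatter when the group at this position was changed. Compound 4 is therefore expected to stay close to compound 3, with a 1.1-fold lower number from compound 3 to compound 4 (0.03 log units; within the scatter). The estimate for compound 4 in this assay is 100 ug/mL, with a range from 60 ug/mL to 170 ug/mL.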

Compound 4, half-maximal inhibitory concentration: 98 ug/mL
Estimate against measurement, compound 4: 1.0-fold (0.01 log units) above; the measured number falls inside the stated range.
By their numbers in this assay, from the lowest: compounds 2, 1, 4 and 3 (each within the scatter of the next).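

Among these compounds, exchanging the oxygen of furan-2-yl for the sulfur of thiophen-2-yl is the first step here that alters only the hetero atom of a five-membered aromatic ring, and in this assay it gives a 1.1-fold lower number from compound 3 to compound 4 (0.04 log units; within the scatter). Compound 4 also cannot be told apart from the two compounds that carry substituted phenyl groups, with a 1.4-fold higher number from compound 2 to compound 4 (0.15 log units; within the scatter) and a 1.1-fold higher number from compound 1 to compound 4 (0.05 log units; within the scatter), so four different aromatic groups on this carbon, ortho to a cyano group, now read alike within the scatter. No measurement offered here explains this sameness, so the data record it without accounting for it.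

Going by these compounds, all four groups are aromatic rings, so it remains open whether an amine, a carboxylic acid or a longer alkyl chain at this position would give a number beyond the scatter of these four. The thiophene joined through its 3-position is also absent from this set, as is any change elsewhere on the shared core, such as a carboxylic acid in place of the ethyl ester.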